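Benzyl for phenyl on the amide nitrogen of compound 3

The compounds below may be only part of what the source reports. "The series", "measured", "known", "first", "only" and "open" are said of these compounds alone.

Compound 1 `O=C(CCSc1nnc(-c2ccncc2)s1)Nc1ccc(Cl)cc1`: in an ADME assay on BHK-21 cells (Mesocricetus auratus) for cytotoxicity, with a stated time of 3 days (a higher number here means that more compound is tolerated, a lower number that less compound is tolerated), compound 1 gives 8210 nM.
Compound 2 `CC(Sc1nnc(-c2ccncc2)s1)C(=O)NCc1ccccc1Cl`: compound 2 reaches only a limit of the assay, > 50000 nM.
Compound 3 `CC(Sc1nnc(-c2ccncc2)s1)C(=O)Nc1ccccc1`: compound 3 also reaches only a limit, > 50000 nM.

Compound 3 therefore has no number of its own in this assay, only a limit, so its place cannot be fixed against compound 1, which does carry a number. Among the compounds with values here, the one step between measured neighbours, a step that the two limits leave unreadable from compound 2 to compound 3, is unreadable because the limit of > 50000 nM in this assay, at which 2 of the 3 values shown sit, catches both of its compounds.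

Compound 4 `CC(Sc1nnc(-c2ccncc2)s1)C(=O)NCc1ccccc1` differs from compound 3 in one place: benzyl in place of phenyl on an amide-type nitrogen. Compound 2 carries a benzyl-type group on the same nitrogen, and the two limits for compound 2 and compound 3 show that neither the 2-chlorobenzyl nor the phenyl version is toxic within the tested range. On that basis the step that the limit leaves unreadable from compound 3 to compound 4 is expected to be none beyond the scatter, with compound 4 most likely again reaching only the limit. The estimate for compound 4 in this assay is 60000 nM, within a range from 20000 nM to 200000 nM.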

Compound 4, half-maximal cytotoxic concentration: > 50000 nM
Compound 4: only a limit was reported; the forecaster's own chance of this, stated with the estimate: 70%; the middle value is on the limit's open side.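

Compound 4 joins compound 2 and compound 3 in giving only a limit in this assay, so neither step to compound 4 can be read, because all three stop at the same limit: the limit of > 50000 nM in this assay, at which 3 of the 4 values shown sit.

The compounds shown leave open whether the phenyl, benzyl and 2-chlorobenzyl versions differ at all in this respect.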